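A Trifluoromethylphenyl Variant in a Series Near the Assay Limit

The compounds below may be only part of what the source reports. "The series", "measured", "known", "first", "only" and "open" are said of these compounds alone.

Compound 1, `OC[C@H]1O[C@@H](n2cnc3c(NCc4ccc(Cl)cc4)ncnc32)[C@H](O)[C@@H]1O`, in a functional assay on K562 cells (Homo sapiens) for antiproliferative activity, with a stated time of 72 h; a higher number here means a weaker inhibitor, a lower number a stronger inhibitor: 218000 nM.
Compound 2, `Cc1cccc(CNc2ncnc3c2ncn3[C@@H]2O[C@H](CO)[C@@H](O)[C@H]2O)c1`, in this assay: > 166000 nM, a limit of the assay.
Compound 3, `COc1cc(CNc2ncnc3c2ncn3[C@@H]2O[C@H](CO)[C@@H](O)[C@H]2O)cc(OC)c1`, in this assay: > 166000 nM, a limit of the assay.

Compound 3 stands at the limit of this assay; its value is a limit, not a number. Of the three compounds measured, only compound 1 has a read number, and that number sits close to the limit itself. Compound 4, `OC[C@H]1O[C@@H](n2cnc3c(NCc4cccc(C(F)(F)F)c4)ncnc32)[C@H](O)[C@@H]1O`, differs from compound 3 in one place: 3-(trifluoromethyl)phenyl in place of 3,5-dimethoxyphenyl on a saturated chain carbon bound to a nitrogen on an aromatic ring. For the measured compounds named here, the steps that bear on this change are a step that the limit leaves unreadable from compound 1 to compound 3 and a step that the two limits leave unreadable from compound 2 to compound 3; both are left unreadable by the limit and give no size, and a step that the limit leaves unreadable from compound 1 to compound 2 is unreadable in the same way. Going by the values given here, because of the limit of > 166000 nM in this assay, at which 2 of the 3 values shown sit, nothing measured so far shows any variation on this aromatic ring moving the compounds into a readable range. Compound 4 is therefore expected to show a step that the limit leaves unreadable from compound 3 to compound 4, a step within the scatter rather than in either direction. Compound 4 is expected to give about 200000 nM, in a range from 100000 nM to 400000 nM, with a fair chance that only a limit is reported again.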

Compound 4, half-maximal inhibitory concentration: > 166000 nM
Compound 4 gave a limit, no number; the forecaster's own chance of this, stated with the estimate: 60%; the middle value lies beyond the limit too.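

In this assay, compound 4 gives > 166000 nM, a limit of the assay and not a number. The steps to compound 4 from compound 1, compound 2 and compound 3 therefore cannot be read. The compounds shown leave open whether any aryl group at this place would give a clearly readable value, and one result dominates the set: the limit of > 166000 nM in this assay, at which 3 of the 4 values shown sit.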